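Exchanging an aryl sulfone for a dimethylsulfonamide

The compounds below may be only part of what the source reports. "The series", "measured", "known", "first", "only" and "open" are said of these compounds alone.

Three ureas sharing a common core have been measured in an assay on isolated protein for activation of Nicotinamide phosphoribosyltransferase (Homo sapiens); on this read-out higher numbers stand for an effect only at larger amounts of compound and lower numbers for an effect already at smaller amounts. Compound 1 `CCOC(=O)c1ccc(NC(=O)NCc2cc[nH]n2)cc1` gives 69000 nM, compound 2 `O=C(NCc1ccncc1)Nc1ccc(S(=O)(=O)c2cccc(Cl)c2)cc1` gives 69 nM, and compound 3 `O=C(NCc1cn[nH]c1)Nc1ccc(S(=O)(=O)c2ccc(Cl)cc2)cc1` gives 23 nM. On these numbers compound 2 holds the second highest value of the three: compound 3 lies nearest, with a lower number beyond the scatter, while compound 1 lies farthest, with a much higher number, also beyond the scatter. Compound 4 `CN(C)S(=O)(=O)c1ccc(NC(=O)NCc2ccncc2)cc1` has not yet been tested in this assay. It differs from compound 2 in a single place: dimethylamino in place of 3-chlorophenyl on a sulfonyl sulfur. Among the measured compounds shown here, no measured pair shows this exact change, so its size cannot be read off directly. For the measured compounds named here, the one compound carrying no sulfonyl group, compound 1, also has by far the highest number, though it differs in other places too. The author expects the number for compound 4 to rise well beyond the scatter, estimated at 3000 nM with a range from 500 nM to 20000 nM, a step of a 43-fold higher number from compound 2 to compound 4 (1.64 log units; beyond the scatter).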

Compound 4, half-maximal effective concentration: 3110 nM
Beside the measured number, compound 4's estimate is 1.0-fold (0.02 log units) below it; low and high end bracket the measured number.
By their numbers in this assay, from the lowest: compound 3; then compound 2; then compound 4; then compound 1.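

In this assay, a 45-fold higher number from compound 2 to compound 4 (1.65 log units; beyond the scatter) gives the first measured size for a single change at this position, and it lies beyond the scatter. Compound 4 keeps the sulfonyl group, so its presence alone does not hold the number at the level of compound 2; the change removes the six-membered aromatic ring of carbon and its chlorine, while the listed counts of hydrogen-bond donors and acceptors and the net charge of the exchanged group stay the same. Nothing measured here accounts for the size of this step.

The compounds shown leave open whether the step follows the loss of the ring or of its chlorine, which a plain phenyl on the sulfonyl sulfur would help to separate. They also leave open how a cyclic amine such as piperidine would behave in this place.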